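The source may report more compounds than this note shows. Statements on the series, on what has been measured and on what is new or still open speak of the compounds shown alone.

Compound 3 `COc1cc(CC2C(C#N)=C(N)N(c3ccc(S(N)(=O)=O)cc3)C3=C2C(=O)CCC3)ccc1O` has the lowest number of the three measured in a functional assay on Ehrlich cells (Mus musculus) for antiproliferative activity, read by trypan blue exclusion, with a stated time of 2 h, tested at 10 ug/mL (on this read-out lower numbers stand for a weaker effect and higher numbers for a stronger effect at the one concentration tested), where compound 3 gives 0%, although its gap to compound 1 lies within the usual scatter. Compound 1 `N#CC1=C(N)N(c2ccc(S(N)(=O)=O)cc2)C2=C(C(=O)CCC2)C1c1ccccc1` gives 10%, and compound 2 `N#CC1=C(N)N(c2ccc(S(N)(=O)=O)cc2)C2=C(C(=O)CCC2)C1c1ccc(O)cc1` gives 90%. Compound 4 `N#CC1=C(N)N(c2ccc(S(N)(=O)=O)cc2)C2=C(C(=O)CCC2)C1c1c(O)ccc2ccccc12` differs from compound 3 by 2-hydroxynaphthalen-1-yl in place of 4-hydroxy-3-methoxybenzyl on a saturated ring carbon. Among the compounds with values here, two measured steps bear on this change: a number 10 percentage points lower from compound 1 to compound 3 (within the scatter), whereas a number 90 percentage points lower from compound 2 to compound 3 (beyond the scatter). The entering 2-hydroxynaphthalen-1-yl carries a hydroxy on an aromatic ring, as does the 4-hydroxyphenyl of compound 2, so the same benzyl group that accompanies the low number of compound 3 leaves. A rise is therefore expected, of uncertain size: a number 50 percentage points higher from compound 3 to compound 4 (beyond the scatter). Compound 4 is estimated at 50%, with a range from 10% to 90%.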

Compound 4, a percentage reported as activity, at one concentration (the size of the read-out at that concentration, not a potency): 0%
Compound 4: the middle estimate sits 50 percentage points above what was measured; measured number outside the range, below it.
By their numbers in this assay, from the lowest: compounds 3, 4 and 1 (each within the scatter of the next); then compound 2.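

In this assay, a hydroxy on an aromatic ring does not by itself bring a high number at this saturated ring carbon: with 2-hydroxynaphthalen-1-yl in place of 4-hydroxyphenyl, the result is a number 90 percentage points lower from compound 2 to compound 4 (beyond the scatter). The same group in place of 4-hydroxy-3-methoxybenzyl gives no change at the digits printed from compound 3 to compound 4 (within the scatter), and in place of phenyl it gives a number 10 percentage points lower from compound 1 to compound 4 (within the scatter), so only the 4-hydroxyphenyl of compound 2 stands apart. Nothing measured here gives a reason for this.

The compounds shown cannot separate the place of the hydroxy from the second aromatic ring, which a 2-hydroxyphenyl group could do. As far as these compounds go, it also remains open whether an amine or a carboxylic acid in place of the hydroxy of compound 2 would keep its number.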